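This account rests on a few compounds, and the source may have more. Where it says the series, first, only, none or still open, it means among the compounds named here.

Working notes on the series. Compound 1 `COc1cc(C)cc(-c2c(-c3ccnc(-c4ccc(C(C)=O)cc4)c3)cnn2CC#N)c1`, compound 2 `Cc1cc(O)cc(-c2nn(CC#N)cc2-c2ccnc(-c3ccc(Oc4ccccc4)cc3)c2)c1`, compound 3 `COc1cc(C)cc(-c2nn(CC#N)cc2-c2ccnc(-c3ccc(N(C)C)cc3)c2)c1` and compound 4 `Cc1cc(O)cc(-c2nn(CC#N)cc2-c2ccnc(-c3ccc(N(C)C)cc3)c2)c1` share one core. In a functional assay on U-251 cells (Homo sapiens) for inhibition, read by sulforhodamine B assay, with a stated time of 48 h (on this read-out lower numbers stand for higher toxicity in this test and higher numbers for lower toxicity in this test), compound 1 reaches only a limit of the test, > 100000 nM. Compound 3 likewise stops at a limit in this assay, > 100000 nM. Both therefore sit at the limit of > 100000 nM in this assay, at which 2 of the 3 values shown sit. Compound 2 gives a number in this assay, 5560 nM. Among the compounds with values here, compound 4 differs from compound 3 in one place, (hydrogen in place of methyl on an oxygen on an aromatic ring); no measured pair isolates this change. From the compounds shown here alone, compound 2 carries the hydroxy group within a different pairing of substituents, so the change's own weight is unknown. The expected step of an at least 3.3-fold lower number from compound 3 to compound 4 (0.52 log units; beyond the scatter) is toward a lower number, held loosely. For compound 4 the estimate is 30000 nM, between 4000 nM and 200000 nM.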

Compound 4, concentration lethal to 50% of the cells: 61300 nM
Compound 4: middle estimate off by 2.0-fold (0.31 log units), on the low side, and the stated range covers the measured number.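

In this assay, the change from methoxy to hydroxy on the aromatic ring now has a reading: an at least 1.6-fold lower number from compound 3 to compound 4 (0.21 log units; that floor lies within the scatter). Within the data shown here, with the hydroxy group held constant, dimethylamino in place of phenoxy gives an 11-fold higher number from compound 2 to compound 4 (1.04 log units; beyond the scatter), the first step at that place read from two numbers. The methoxy to hydroxy step remains only a floor, compound 3 standing at a limit of the test: the limit of > 100000 nM in this assay, at which 2 of the 4 values shown sit.

Open, from the compounds shown here alone, is whether phenoxy keeps this reading with methoxy in place of hydroxy. Also open, going by these compounds, is how a carboxylic acid or a longer amine chain at that place would read with the hydroxy group.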